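Swapping the aryl group on a weak thiazole hydrazone series

This account rests on a few compounds, and the source may have more. Where it says the series, first, only, none or still open, it means among the compounds named here.

Measured compounds:
- Compound 1, `COc1cc(/C=N/Nc2nc(-c3ccc(Br)cc3)cs2)cc(Br)c1OC`: 36200 nM
- Compound 2, `COc1cc(/C=N/Nc2nc(-c3ccc(C(F)(F)F)cc3)cs2)c(Br)c(Br)c1OC`: > 100000 nM
- Compound 3, `COc1cc(/C=N/Nc2nc(-c3cccc(Br)c3)cs2)cc(Br)c1OC`: 43400 nM

The assay is a functional assay on Caco-2 cells (Homo sapiens) for inhibition, read by MTT assay, with a stated time of 48 h; a higher number here means a weaker inhibitor, a lower number a stronger inhibitor. Among the compounds with values here, compound 1 gives 36200 nM and compound 3 gives 43400 nM; the only measured step, a 1.2-fold higher number from compound 1 to compound 3 (0.08 log units; within the scatter), is a move of the bromine on the aryl ring that changes little. Compound 2 stands apart: its result is a limit, not a number, as recorded in the limit of > 100000 nM in this assay, at which 1 of the 3 values shown sits, so compound 2 is only known to be weaker than the assay could resolve.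

Compound 4, `COc1ccccc1-c1csc(N/N=C/c2cc(OC)c(OC)c(Br)c2Br)n1`, keeps everything of compound 2 except the aryl group on the five-membered ring: 2-methoxyphenyl in place of 4-(trifluoromethyl)phenyl on an aromatic carbon. Within the data shown here, no measured step covers this kind of exchange; the step from compound 1 to compound 3 concerns a different position and was within the scatter, so it gives no direction. Starting from a limit, the expected step from compound 2 to compound 4 is an at least 1.1-fold lower number from compound 2 to compound 4 (0.04 log units; that floor lies within the scatter), with the estimate for compound 4 being 90000 nM, in the range from 30000 nM to 300000 nM.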

Compound 4, half-maximal inhibitory concentration: > 100000 nM
Compound 4 was reported as a limit; the forecaster's own chance of this, stated with the estimate: 50%; at least 1.1-fold (0.04 log units) between middle value and limit.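

Compound 2 and compound 4 are both reported only as a limit, not as a number, so no step between them can be read: the limit of > 100000 nM in this assay, at which 2 of the 4 values shown sit.

The compounds shown leave open whether 2-methoxyphenyl or 4-(trifluoromethyl)phenyl gives the weaker inhibitor, and how far past the limit either compound lies.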